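Trimming a methoxy from a dimethoxybenzyl amine

The source may hold more compounds than are shown below. What is called first, only, known or untested is meant among the compounds shown, and "the series" means these compounds.

Measured compounds:
- compound 1 `COc1ccc(CNc2nc3cc(N)cc(N)c3nc2-c2ccccc2)cc1OC`: 30200 nM
- compound 2 `COc1cc(CNc2nc3cc(N)cc(N)c3nc2-c2ccccc2)cc(OC)c1OC`: 17800 nM

Of the compounds shown here, two sharing one core have been measured in a functional assay on SK-MEL-28 cells (Homo sapiens) for inhibition, read by sulforhodamine B assay, with a stated time of 48 h; on this read-out higher numbers stand for weaker inhibition of growth and lower numbers for stronger inhibition of growth. Compound 1 gives 30200 nM, the highest of the two numbers; its nearest neighbour is compound 2, with 17800 nM. For the measured compounds named here, the only measured step, a 1.7-fold lower number from compound 1 to compound 2 (0.23 log units; within the scatter), adds a methoxy group, and its size is within the scatter, so the two values cannot be told apart.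

Compound 3 `COc1ccc(CNc2nc3cc(N)cc(N)c3nc2-c2ccccc2)cc1` has not been measured. It differs from compound 1 in one place: hydrogen in place of methoxy on an aromatic carbon. Going by the values given here, this is the reverse kind of change to the one measured step, taking a methoxy away rather than adding one. Since the addition in a 1.7-fold lower number from compound 1 to compound 2 (0.23 log units; within the scatter) left the number essentially where it was, the removal in compound 3 is expected to do much the same, with no clear movement in this assay beyond the scatter in either direction.

For compound 3 the expected value in this assay is 35000 nM, with a range from 15000 nM to 80000 nM, which corresponds to an estimated step of a 1.2-fold higher number from compound 1 to compound 3 (0.06 log units; within the scatter).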

Compound 3, concentration for total growth inhibition: 32400 nM
The estimate for compound 3 lay 1.1-fold (0.03 log units) above the measured number; low and high end bracket the measured number.
By their numbers in this assay, from the lowest: compounds 2, 1 and 3 (each within the scatter of the next).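

In this assay, going from 3,4-dimethoxyphenyl to 4-methoxyphenyl gives a 1.1-fold higher number from compound 1 to compound 3 (0.03 log units; within the scatter). Together with the earlier addition of a methoxy group, a 1.7-fold lower number from compound 1 to compound 2 (0.23 log units; within the scatter), this means that compound 1 now has a measured step in each direction, taking a methoxy group away as well as adding one, and neither step can be told apart from the scatter, so the methoxy group that leaves here, ortho to a methoxy group and meta to a large group, can be replaced by hydrogen with no detectable effect on the number in this assay. No supporting measurement is available to explain this result.

The compounds shown all keep the methoxy group that remains in compound 3, so they do not tell whether a ring with hydrogen in its place would give a different number. They also leave open whether a group other than methoxy on the carbon that changed here, such as a hydroxyl, a chlorine or an amine, would move the number beyond the scatter.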